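Aryl change on the five-membered ring nitrogen

The compounds below may be only part of what the source reports. "The series", "measured", "known", "first", "only" and "open" are said of these compounds alone.

Compound 1 `CCOC(=O)C1=Cc2ccccc2OC1(OCc1cn(-c2cccc(OC)c2)nn1)C(F)(F)F` stands only at a limit of a functional assay on DU-145 cells (Homo sapiens) for inhibition, read by MTT assay, with a stated time of 24 h; on this read-out lower numbers stand for stronger inhibition and higher numbers for weaker inhibition: in this assay compound 1 gives > 150000 nM, which is a limit of the assay and not a number (the limit of > 150000 nM in this assay, at which 1 of the 2 values shown sits). Compound 2 `CCOC(=O)C1=Cc2ccccc2OC1(OCc1cc(-c2ccc(Br)cc2)no1)C(F)(F)F` is not a one-place neighbour of compound 1; in this assay compound 2 gives 71700 nM. Compound 3 `CCOC(=O)C1=Cc2ccccc2OC1(OCc1cn(-c2ccc(F)c(Cl)c2)nn1)C(F)(F)F` differs from compound 1 by 3-chloro-4-fluorophenyl in place of 3-methoxyphenyl on an aromatic nitrogen. Within the data shown here, no step between measured compounds is available, so the size of this change is open; weak inhibition is expected to remain, and the step of an at least 1.2-fold lower number from compound 1 to compound 3 (0.09 log units; that floor lies within the scatter) is expected to stay within the usual scatter. Compound 3 is estimated at 120000 nM, between 50000 nM and 300000 nM.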

Compound 3, half-maximal inhibitory concentration: 21500 nM
For compound 3 the middle estimate is 5.6-fold (0.75 log units) above the measured one; the whole stated range lies above it.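

On an aromatic nitrogen of a five-membered aromatic ring, the aryl group changes the read-out in this assay: 3-chloro-4-fluorophenyl in place of 3-methoxyphenyl gives an at least 6.9-fold lower number from compound 1 to compound 3 (0.84 log units; beyond the scatter) and brings a triazole-bearing compound into measurable range. The size of this step is open on one side, because compound 1 stands at a limit of the assay and not at a number: the limit of > 150000 nM in this assay, at which 1 of the 3 values shown sits.

One pair cannot separate the part of the chlorine, the fluorine and the lost methoxy group. As far as these compounds go, how an aryl group carrying an amine or a carboxylic acid would read at this position stays open.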